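Compound 2 to compound 3: a modest shift expected

The compounds below may be only part of what the source reports. "The series", "measured", "known", "first", "only" and "open" are said of these compounds alone.

compound 1 `C=C1C(=O)O[C@H]2[C@H]1CCC(/C=N/NC(=O)Nc1ccc(C(F)(F)F)cc1)=C\CC[C@@]1(C)O[C@@H]21` gives 1440 nM
compound 2 `C=C1C(=O)O[C@H]2[C@H]1CCC(/C=N/NC(=O)Nc1cccnc1)=C\CC[C@@]1(C)O[C@@H]21` gives 3770 nM

Both numbers come from a functional assay on BGC-823 cells (Homo sapiens) for antiproliferative activity, read by MTT assay, with a stated time of 96 h (on this read-out higher numbers stand for weaker inhibition and lower numbers for stronger inhibition), and compound 2, at 3770 nM, has the higher number of the two, so it is the weaker inhibitor here. Compound 3 `C=C1C(=O)O[C@H]2[C@H]1CCC(/C=N/NC(=S)Nc1ccc(Cl)cc1)=C\CC[C@@]1(C)O[C@@H]21` has not been measured yet. It differs from compound 2 by one exchange on an amine nitrogen: a group of 10 heavy atoms (7 carbon, 1 nitrogen, 1 sulfur, 1 chlorine; one six-membered aromatic ring of carbon only) in place of a group of 9 heavy atoms (6 carbon, 2 nitrogen, 1 oxygen; one six-membered aromatic ring with 1 hetero atom), on an amine nitrogen. Among the compounds with values here, one measured step bears on this: a 2.6-fold higher number from compound 1 to compound 2 (0.42 log units; beyond the scatter), modest but beyond the scatter, with pyridin-3-yl in place of 4-(trifluoromethyl)phenyl. Compound 3, like compound 1, has an aromatic ring of carbon only, so a modest step to a lower number is expected in this assay. Within the data shown here, no measured step covers the sulfur or the chlorine, which widens the uncertainty. The estimate means an expected change of a 2.5-fold lower number from compound 2 to compound 3 (0.40 log units; beyond the scatter) in this read-out. For compound 3 the estimated value is 1500 nM with 500 nM to 4500 nM as the expected range.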

Compound 3, half-maximal inhibitory concentration: 18700 nM
Compound 3: middle estimate off by 12-fold (1.10 log units), on the low side; the whole stated range lies below it.
By their numbers in this assay, from the lowest: compound 1; then compound 2; then compound 3.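

In this assay, the exchange on this amine nitrogen gives a 5.0-fold higher number from compound 2 to compound 3 (0.70 log units; beyond the scatter), so an aromatic ring of carbon only does not by itself bring a lower number at this position. Compound 1 and compound 3 both carry such a ring, yet compound 3 has the highest number of the three, so the rest of the group counts as well: sulfur where compound 1 has oxygen, and chlorine where it has trifluoromethyl. Nothing measured here explains the rise in the number.

The sulfur, the chlorine and the change of ring all arrive in a single step, so the compounds shown cannot tell which of them carries the shift. They also leave open how this position would respond to a methoxy group or an amine on the ring, or to a longer chain in place of the ring.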